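A few compounds are considered here, and "the series" means these few. Any claim that something is new, unique, unknown or untested is made for them only; others in the source may bear on it.

Three compounds share one core and differ only in the aromatic group attached to the sulfur. Compound 1 `COc1ccc(SCc2ccc(/C=C/C(=O)Nc3ccccc3N)cc2)cc1OC` carries a 3,4-dimethoxyphenyl there, and in a functional assay on HCT-116 cells (Homo sapiens) for inhibition, read by CCK-8 assay, with a stated time of 72 h, tested at 8 uM (on this read-out higher numbers stand for more inhibition of growth at the one concentration tested and lower numbers for less inhibition of growth), compound 1 gives 49.5%. Compound 2 `Cc1cc(C)cc(SCc2ccc(/C=C/C(=O)Nc3ccccc3N)cc2)c1` carries a 3,5-dimethylphenyl, and in this assay compound 2 gives 4.2%, the second highest of the three numbers, while compound 3 `Nc1ccccc1NC(=O)/C=C/c1ccc(CSc2cccc(F)c2)cc1` carries a 3-fluorophenyl and in this assay compound 3 gives 3.22%. The step of a number 45.3 percentage points lower from compound 1 to compound 2 (beyond the scatter) and the step of a number 46.3 percentage points lower from compound 1 to compound 3 (beyond the scatter) are both large, whereas the step of a number 1 percentage points lower from compound 2 to compound 3 (within the scatter) lies within the scatter.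

Compound 4 `CCc1ccc(SCc2ccc(/C=C/C(=O)Nc3ccccc3N)cc2)cc1` differs from compound 2 by 4-ethylphenyl in place of 3,5-dimethylphenyl on a sulfur. The step that bears most directly on this is a number 1 percentage points lower from compound 2 to compound 3 (within the scatter), where one group without methoxy substituents replaced another on the sulfur and the number barely moved. A change of the same kind is now made, so no step beyond the scatter is expected in this assay. The step expected from compound 2 to compound 4 is a number 1.8 percentage points higher from compound 2 to compound 4 (within the scatter). For compound 4, the estimate is 6%, with a range from 0% to 20%.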

Compound 4, percent growth inhibition at one concentration: 2.68%
The estimate for compound 4 lay 3.3 percentage points above the measured number; the range from low to high includes it.
By their numbers in this assay, from the lowest: compounds 4, 3 and 2 (each within the scatter of the next); then compound 1.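

Rearranging the same atoms, from 3,5-dimethylphenyl to 4-ethylphenyl on the sulfur, has no readable effect in this assay: the result is a number 1.5 percentage points lower from compound 2 to compound 4 (within the scatter). The 4-ethylphenyl and 3-fluorophenyl groups also cannot be told apart, with a number 0.5 percentage points lower from compound 3 to compound 4 (within the scatter), so compounds 2, 3 and 4 now form a group of three with low numbers, while the 3,4-dimethoxyphenyl of compound 1 stands alone, as the large a number 46.8 percentage points lower from compound 1 to compound 4 (beyond the scatter) shows. No measurement available here explains why the 3,4-dimethoxyphenyl group differs from the other three.

The compounds shown leave open whether both methoxy groups are needed or a single one, as in 4-methoxyphenyl, would be enough. They also leave open how a phenyl carrying an amine or a carboxylic acid would behave at this position.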